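Swapping the benzimidazole for a chloropyrazole

A few compounds are considered here, and "the series" means these few. Any claim that something is new, unique, unknown or untested is made for them only; others in the source may bear on it.

Three compounds have been measured in a functional assay on U2OS cells for antagonist activity at C-X-C chemokine receptor type 3 (Homo sapiens), read by beta-arrestin recruitment; a higher number here means a weaker inhibitor, a lower number a stronger inhibitor:

Compound 1 `C[C@H]1CN(c2scnc2-c2nc3ccccc3[nH]2)CCN1C(=O)Cn1cnc2cccnc21` gives 8030 nM.
Compound 2 `C[C@@H]1CN(c2sc(C3CC3)nc2-c2nc3ccccc3[nH]2)CCN1C(=O)Cn1cnc2cccnc21` gives 745 nM.
Compound 3 `CCOc1ncc(-c2nc(C(F)(F)F)sc2N2CCN(C(=O)Cn3cnc4ccccc43)[C@H](C)C2)cn1` gives 49 nM.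

Compound 3 has the lowest number of the three and is the strongest inhibitor here; compound 2 stands well above it and compound 1 higher still, both gaps beyond the usual scatter. Compound 4 `CCOc1ncc(-c2nc(C(F)(F)F)sc2N2CCN(C(=O)Cn3cc(Cl)cn3)[C@H](C)C2)cn1` differs from compound 3 in one place: 4-chloro-1H-pyrazol-1-yl in place of 1H-benzimidazol-1-yl on a saturated chain carbon bound to a carbonyl carbon. Going by the values given here, no measured pair shows the effect of this change on its own, since compounds 1 and 2 differ from compound 3 in several places at once. The expected step is a moderate rise in the number, estimated at a 3.1-fold higher number from compound 3 to compound 4 (0.49 log units; beyond the scatter). Compound 4 is therefore expected to give 150 nM, with a likely range from 40 nM to 600 nM.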

Compound 4, half-maximal inhibitory concentration: 272 nM
Compound 4: the middle estimate sits 1.8-fold (0.26 log units) below what was measured; the measured number falls inside the stated range.
By their numbers in this assay, from the lowest: compound 3; then compound 4; then compound 2; then compound 1.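

In this assay, going by these compounds alone, 4-chloro-1H-pyrazol-1-yl in place of 1H-benzimidazol-1-yl on a saturated chain carbon bound to a carbonyl carbon gives the first single-place comparison in this set (a 5.6-fold higher number from compound 3 to compound 4 (0.74 log units; beyond the scatter)). Inhibition at this position therefore weakens when the six-membered aromatic ring of carbon only is lost and a chlorine is gained, but it does not disappear. Nothing available explains this step.

As far as these compounds go, both parts of the change arrive together, so the share of each remains open. An unsubstituted 1H-pyrazol-1-yl, or a pyrazole carrying a methyl or a nitrile in place of the chlorine, would help separate them.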